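A Carboxyphenyl Tetrazole Analog and Its Expected Stability

A few compounds are considered here, and "the series" means these few. Any claim that something is new, unique, unknown or untested is made for them only; others in the source may bear on it.

In an ADME assay on S9 fraction from liver (Rattus norvegicus) for metabolic stability, read by LC-MS, using NADPH, with a stated time of 30 min (a higher number here means that more of the compound is left, a lower number that less of the compound is left), compound 3 `CCCCCCCCc1ccc(OCC(=O)Cn2nnnc2SC)cc1` gives 21%, the lowest of the two numbers shown; compound 2 `CCCCCCCCc1ccc(OCC(=O)Cn2nnc(C(=O)O)n2)cc1` gives 52%. Compound 1 `CCCCCCCCc1ccc(OCC(=O)Cn2ncnn2)cc1` sits at the assay limit of < 5%. Compound 4 `CCCCCCCCc1ccc(OCC(=O)Cn2nnnc2-c2cccc(C(=O)O)c2)cc1` differs from compound 3 by 3-carboxyphenyl in place of methylsulfanyl on an aromatic carbon. Among the compounds with values here, no measured step alters this aromatic carbon, but the step of a number at least 47 percentage points higher from compound 1 to compound 2 (beyond the scatter) shows a carboxy added on an aromatic carbon raising the result, and the step of a number 31 percentage points lower from compound 2 to compound 3 (beyond the scatter) shows the result falling when the carboxy-bearing group is exchanged. The entering 3-carboxyphenyl again brings a carboxy, so a rise beyond the scatter is expected, a number 19 percentage points higher from compound 3 to compound 4 (beyond the scatter). Compound 4 is therefore estimated at 40%, between 15% and 70%.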

Compound 4, percent of the compound remaining: < 5%
Compound 4: no number, only a limit (the forecaster's own chance of this, stated with the estimate: 10%); at least 35 percentage points between middle value and limit.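

In this assay, 3-carboxyphenyl in place of methylsulfanyl on the aromatic carbon between two ring nitrogen atoms gives a number at least 16 percentage points lower from compound 3 to compound 4 (beyond the scatter). A carboxy therefore does not go with a higher result at every place, as the earlier step, a number at least 47 percentage points higher from compound 1 to compound 2 (beyond the scatter), alone might suggest. Compound 4 gives < 5%, which is a limit and not a number: the limit of < 5% in this assay, at which 2 of the 4 values shown sit.

The compounds shown leave open whether the carboxy or the six-membered aromatic ring goes with this fall. On these data alone, how a plain phenyl or a short chain ending in a carboxylic acid would read on this carbon also remains open.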